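The source may hold more compounds than are shown below. What is called first, only, known or untested is meant among the compounds shown, and "the series" means these compounds.

Working notes on the series. In an in vitro ADME assay on microsomes from liver (Rattus norvegicus) for metabolic stability (a lower number here means slower removal, a higher number faster removal of the compound), compound 1 `CC[C@H](C)[C@@H]1C(=O)N[C@H](C2Cc3ccccc3C2)C(=O)N1[C@@H](C(=O)N1CCOCC1)c1cnc(C)cc1C` gives 1 mL.min-1.g-1, compound 2 `CCC(CC)[C@@H]1C(=O)N[C@H](C2Cc3ccccc3C2)C(=O)N1[C@@H](C(=O)N1CCOCC1)c1ccc(C)nc1` gives 1 mL.min-1.g-1 and compound 3 `CC[C@H](C)[C@@H]1C(=O)N[C@H](C2Cc3ccccc3C2)C(=O)N1[C@@H](C(=O)N(C)C)c1ccc(C)nc1C` gives 1 mL.min-1.g-1. Compound 3 therefore stands level with compound 1 and compound 2 at the digits reported, and the three values show no spread.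

Compound 4 `CC[C@H](C)[C@@H]1C(=O)N[C@H](C2Cc3ccccc3C2)C(=O)N1[C@@H](C(=O)N(C)C)c1cc(C)cnc1C` has the same atoms as compound 3, joined differently, and the two differ in one place: 2,5-dimethylpyridin-3-yl in place of 2,6-dimethylpyridin-3-yl on a saturated chain carbon bound to an amide-type nitrogen in a ring and a carbonyl carbon.

Among the compounds with values here, no measured pair differs in one place only, so no size of step can be read directly from this assay. The expectation rests on the level values alone, with compound 1 at 1 mL.min-1.g-1 and compound 3 at 1 mL.min-1.g-1. The expected step of no change at the digits printed from compound 3 to compound 4 (within the scatter) is none beyond the scatter, with no direction favoured. For compound 4 the estimated intrinsic clearance in microsomes is 1 mL.min-1.g-1, with an expected range of 0.5 mL.min-1.g-1 to 3 mL.min-1.g-1.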

Compound 4, intrinsic clearance in microsomes: 1 mL.min-1.g-1
Compound 4: middle estimate and measured number agree at the digits printed, within the range that was stated.
By their numbers in this assay, from the lowest: compounds 1, 2, 3 and 4 (each within the scatter of the next).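

In this assay the series now has its first pair differing in one place only, and the step reads no change at the digits printed from compound 3 to compound 4 (within the scatter). At this place, on a saturated chain carbon bound to an amide-type nitrogen in a ring and a carbonyl carbon, 2,5-dimethylpyridin-3-yl and 2,6-dimethylpyridin-3-yl therefore read alike, with the same atoms joined differently. Nothing measured here offers an explanation for this result.

As far as these compounds go, whether a carboxylic acid or a primary amine at this place would move the read-out in this assay beyond the scatter remains open. Also open is whether the same exchange of dimethylpyridinyl groups would read alike with the other amide of compound 1 or the other chain of compound 2, since no such pair is shown.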